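The source may report more compounds than this note shows. Statements on the series, on what has been measured and on what is new or still open speak of the compounds shown alone.

Compound 1 `CCCNc1ncnc2c1cnn2-c1ccccc1` is the starting point of this account. In a functional assay on G-361 cells (Homo sapiens) for cytotoxicity, read by sulforhodamine B assay (on this read-out lower numbers stand for higher toxicity in this test and higher numbers for lower toxicity in this test), compound 1 gives > 100000 nM, which is a limit of the assay and not a number. Compound 2 `Cc1nc(NC(C)C)c2cnn(-c3ccccc3)c2n1` gives > 100000 nM in this assay, again only a limit. Compound 3 `Cc1nc(NCc2ccco2)c2cnn(-c3ccccc3)c2n1` gives > 100000 nM in this assay, also a limit. The step that the two limits leave unreadable from compound 2 to compound 3 therefore cannot be read, and all three values sit at the limit of > 100000 nM in this assay, at which 3 of the 3 values shown sit. Compound 4 `CCCNc1nc(CC)nc2c1cnn2-c1ccccc1` differs from compound 1 by ethyl in place of hydrogen on an aromatic carbon. For the measured compounds named here, no measured step bears directly on this change, and the single step available is unreadable, so no movement beyond the scatter can be anticipated in this assay. Compound 4 is therefore expected to give 100000 nM (between 30000 nM and 300000 nM), an expected step of a number no higher from compound 1 to compound 4 (the limit leaves the size open).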

Compound 4, concentration lethal to 50% of the cells: > 100000 nM
Compound 4 was reported as a limit; the forecaster's own chance of this, stated with the estimate: 80%; the middle value sits exactly at the limit.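

No new step can be read between compound 1 and compound 4, whose values in this assay are both limits. As far as these compounds go, whether ethyl in place of hydrogen on an aromatic carbon changes the read-out in this assay stays open.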